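A few compounds are considered here, and "the series" means these few. Any claim that something is new, unique, unknown or untested is made for them only; others in the source may bear on it.

Measured compounds:
compound 1 `CC(C)c1cc2c(N/N=C\c3ccncc3)ncnc2s1` gives > 10 ug/mL in a functional assay on PC-6 cells (Homo sapiens) for antiproliferative activity; a lower number here means a stronger inhibitor, a higher number a weaker inhibitor (a limit of the assay, not a number);
compound 2 `CC(C)c1cc2c(N/N=C\c3ccccc3)ncnc2s1` gives 0.651 ug/mL in this assay.

Within the data shown here, compound 2 gives the only number that is available; the other compound, compound 1, sits at a limit of the assay, (the limit of > 10 ug/mL in this assay, at which 1 of the 2 values shown sits). Among the measured compounds shown here, the one measured step, an at least 15-fold lower number from compound 1 to compound 2 (1.18 log units; beyond the scatter), shows that swapping the six-membered nitrogen-containing ring for a plain phenyl turns a compound at the limit into a measurable inhibitor.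

Compound 3 `CC(C)c1cc2c(N/N=C\c3ccco3)ncnc2s1` is not yet measured. Its difference from compound 2 is furan-2-yl in place of phenyl on a carbon with a double bond to nitrogen. The step from compound 1 to compound 2 bears on this change only loosely: it concerns a different heteroaromatic ring entering at the same place, and it was large. Furan-2-yl is a smaller ring with one oxygen, so some weakening relative to phenyl is expected, but not a return to the limit. The expected step is a 2.3-fold higher number from compound 2 to compound 3 (0.36 log units; beyond the scatter). For compound 3 the estimate in this assay is 1.5 ug/mL, with a likely range from 0.5 ug/mL to 6 ug/mL.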

Compound 3, half-maximal inhibitory concentration: 3.78 ug/mL
Estimate against measurement, compound 3: 2.5-fold (0.40 log units) below; the measured number falls inside the stated range.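

At the carbon with a double bond to nitrogen, the oxygen-containing five-membered ring shows that the loss seen with pyridin-4-yl is not unique to that ring, as furan-2-yl also falls short of phenyl in this assay, with a 5.8-fold higher number from compound 2 to compound 3 (0.76 log units; beyond the scatter). Yet furan-2-yl keeps a measurable value, with an at least 2.6-fold lower number from compound 1 to compound 3 (0.42 log units; beyond the scatter), so the three rings at this place now form an order rather than a simple split between measurable and not: phenyl gives the lowest number, furan-2-yl an intermediate one, and pyridin-4-yl the highest reading. Compound 1 still gives only a limit of the assay and not a number, so the true size of its gap to the other two stays unknown: the limit of > 10 ug/mL in this assay, at which 1 of the 3 values shown sits.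

Furan-2-yl differs from phenyl both in ring size and in carrying an oxygen, and the compounds shown do not separate these two changes. A thiophen-2-yl ring, a pyridin-3-yl ring or a phenyl ring carrying a methoxy group or a chlorine atom would each test this place in a way that these three compounds cannot.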